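This account rests on a few compounds, and the source may have more. Where it says the series, first, only, none or still open, it means among the compounds named here.

Measured compounds:
compound 1 `CN(C)c1ccc(C2CC(c3ccc(-n4cncn4)cc3)=NN2)cc1` — -3.3%
compound 2 `COC(=O)CC(=O)N1N=C(c2ccc(N3CCN(C)CC3)cc2)CC1c1ccc(N(C)C)cc1` — -2.2%

Of the compounds shown here, two have been tested so far in a functional assay on NCI-H1975 cells (Homo sapiens) for inhibition, read by sulforhodamine B assay, tested at 10 uM; on this read-out lower numbers stand for less inhibition and higher numbers for more inhibition at the one concentration tested (going by the name of the read-out). Compound 1 `CN(C)c1ccc(C2CC(c3ccc(-n4cncn4)cc3)=NN2)cc1` gives -3.3%. Compound 2 `COC(=O)CC(=O)N1N=C(c2ccc(N3CCN(C)CC3)cc2)CC1c1ccc(N(C)C)cc1` gives -2.2%. The two numbers lie within the usual scatter of each other, so neither compound can be set apart from the other on this read-out, and both sit at the level where no inhibition is registered.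

Compound 3 `CN1CCN(c2ccc(C3=NN(S(C)(=O)=O)C(c4ccc(N(C)C)cc4)C3)cc2)CC1` has not yet been measured in this assay. It differs from compound 2 in one place: methylsulfonyl in place of ((methoxycarbonyl)methyl)carbonyl on an amine nitrogen in a ring. Going by the values given here, no pair of measured compounds shows what such a change does here, so nothing in the data points to a step in either direction. Among the compounds with values here, the only guide is that compound 2 gives -2.2% and compound 1 gives -3.3%, both near zero, and the expectation is therefore that the step of a number 2.2 percentage points higher from compound 2 to compound 3 (within the scatter) will be none beyond the scatter. Compound 3 is accordingly estimated at 0%, within a range from -12% to 14%.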

Compound 3, a percentage reported as inhibition, at one concentration (the size of the read-out at that concentration, not a potency): -1.3%
Estimate against measurement, compound 3: 1.3 percentage points above, within the range that was stated.
By their numbers in this assay, from the lowest: compounds 1, 2 and 3 (each within the scatter of the next).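

On the amine nitrogen in a ring, methylsulfonyl in place of ((methoxycarbonyl)methyl)carbonyl is now a measured change, and in this assay it amounts to a number 0.9 percentage points higher from compound 2 to compound 3 (within the scatter) and so cannot be told from no change at all. The two groups differ in size and make-up, 7 heavy atoms with no sulfur against 4 heavy atoms with 1 sulfur, yet the read-out stays at the level where no inhibition is registered with either of them, so this position has so far shown no response to what it carries. Nothing measured alongside these compounds offers an account of this result.

From the compounds shown here alone, it remains open whether any other group on this nitrogen, such as a carboxylic acid or a primary amine on a longer chain, would register inhibition in this assay at all. Also open, going by these compounds, is whether a change at this position can show up on the shared core, or whether a change elsewhere, such as replacing the 4-(dimethylamino)phenyl group, would first have to lift the read-out away from the level of no inhibition.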